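Adding a Second Fluorine to a Receptor Antagonist Series

This account rests on a few compounds, and the source may have more. Where it says the series, first, only, none or still open, it means among the compounds named here.

Compound 1 `O=C(O)Cc1sc(C(c2ccccc2)c2ccccc2)nc1-c1cccc(F)c1` and compound 2 `O=C(O)Cc1sc(C(c2ccccc2)c2ccccc2)nc1-c1ccc(F)c(F)c1` share one core and differ in a single spot: fluoro in place of hydrogen on an aromatic carbon. In an in vitro functional assay on HEK285-7 cells for antagonist activity at prostaglandin D2 receptor 2 (Homo sapiens), read by BRET and beta-arrestin recruitment (a higher number here means a weaker inhibitor, a lower number a stronger inhibitor), compound 1 gives 29 nM, while compound 2 gives 43 nM. The step of a 1.5-fold higher number from compound 1 to compound 2 (0.17 log units; within the scatter) is therefore small, and the two numbers cannot be told apart with confidence.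

Compound 3 `O=C(O)Cc1sc(C(c2ccc(F)cc2)c2ccc(F)cc2)nc1-c1cccc(F)c1` is built on a different core, and the difference between the two cores is not broken down here. In this assay compound 3 gives 18 nM, a number whose gap to compound 1 lies within the scatter and whose gap to compound 2 lies beyond it.

Compound 4 `O=C(O)Cc1sc(C(c2ccc(F)cc2)c2ccc(F)cc2)nc1-c1cc(F)cc(F)c1` has not yet been measured. It differs from compound 3 in one spot: fluoro in place of hydrogen on an aromatic carbon. Within the data shown here, this is the same kind of change as the one between compound 1 and compound 2, but not the same: in compound 2 the new fluoro sits ortho to a fluoro group and para to a large group, whereas in compound 4 it sits meta to a fluoro group and meta to a large group. The expected step is a 1.4-fold higher number from compound 3 to compound 4 (0.14 log units; within the scatter), resting on the earlier step of a 1.5-fold higher number from compound 1 to compound 2 (0.17 log units; within the scatter), which stayed within the scatter. In this assay compound 4 is expected to give about 25 nM, most likely between 12 nM and 55 nM.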

Compound 4, half-maximal inhibitory concentration: 340 nM
The estimate for compound 4 lay 14-fold (1.13 log units) below the measured number; the measured number lies above the stated range.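

In this assay, putting fluoro in place of hydrogen on the core of compound 3 gives a 19-fold higher number from compound 3 to compound 4 (1.28 log units; beyond the scatter), so compound 4 is a much weaker inhibitor than compound 3. A change that left no readable difference on one core therefore does not carry over with the same size to the other, and a step seen on one core in this series is a poor guide to the next: the same change on two cores in this assay, a 1.5-fold higher number (0.17 log units; within the scatter) from compound 1 to compound 2 and a 19-fold higher number (1.28 log units; beyond the scatter) from compound 3 to compound 4, 13-fold (1.11 log units) apart, beyond the scatter of two such steps. This does not show that the core alone sets the size of the step, since the new fluoro also lands at a different place on the ring in the two pairs, and in compound 4 it sits meta to a fluoro group and meta to a large group; two pairs cannot separate these differences or support a general rule.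

The compounds shown leave open how the 3,5-difluorophenyl group behaves on the core of compound 1, a comparison that would separate the core from the position of the fluoro. They also leave open whether a chloro or methoxy group at the same place on the core of compound 3 would give a step of similar size.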